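The source may report more compounds than this note shows. Statements on the series, on what has been measured and on what is new or still open speak of the compounds shown alone.

Compound 1 `COc1ccc(-c2cc(=O)c3c(OC)cc(OC)cc3n2S(=O)(=O)c2ccc(F)cc2)cc1`: in a functional assay on KOPN-8 cells (Homo sapiens) for antiproliferative activity, with a stated time of 72 h (a lower number here means that less compound is needed, a higher number that more compound is needed for the effect), compound 1 gives > 65500 nM, which is a limit of the assay and not a number.
Compound 2 `COc1ccc(-c2cc(=O)c3c(OC)cc(OC)cc3n2S(=O)(=O)c2ccc(Cl)cc2)cc1`: in this assay compound 2 gives > 34400 nM, again a limit and not a number.
Compound 3 `COC(=O)c1cc(=O)c2cc(NC(=O)Nc3ccc(Cl)c(Cl)c3)ccc2[nH]1`: in this assay compound 3 gives > 6350 nM, also a limit and not a number.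

The change from compound 2 to compound 1 is fluoro in place of chloro on an aromatic carbon, and it made a step that the two limits leave unreadable from compound 2 to compound 1. Compound 4 `COC(=O)c1cc(=O)c2cc(NC(=O)Nc3ccc(F)c(Cl)c3)ccc2[nH]1` differs from compound 3 by fluoro in place of chloro on an aromatic carbon. The difference between the two cores is not broken down here. The surroundings are not the same word for word: in compound 4 the changed carbon is also ortho to a chloro group (1 heavy atom), so this is the same kind of change, not the same one. With the earlier step unreadable and compound 3 itself at a limit, the step that the limit leaves unreadable from compound 3 to compound 4 is expected to be small. Compound 4 is therefore expected at about 15000 nM, between 4000 nM and 60000 nM, most likely reported again as a limit.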

Compound 4, half-maximal effective concentration: > 6350 nM
Compound 4 gave a limit, no number; the forecaster's own chance of this, stated with the estimate: 70%; the middle value does not contradict the limit.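

For the compounds shown here, compound 3 and compound 4 each give only a limit in this assay, not a number, so no step between them can be read. The compounds shown leave open what concentration any of them needs, and whether fluoro in place of chloro on an aromatic carbon changes it.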